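Amine substituent variation on the shared core

This account rests on a few compounds, and the source may have more. Where it says the series, first, only, none or still open, it means among the compounds named here.

Compound 1 `c1ccc2c(c1)CCC2NC1CCN(CCCc2c[nH]c3ccc(-n4cnnc4)cc23)CC1` carries a 2,3-dihydro-1H-inden-1-yl group on the amine nitrogen. Going by the values given here, in an assay on CHO cells for agonist activity at 5-hydroxytryptamine receptor 1D (Homo sapiens), read by GTPgammaS binding (a higher number here means that more compound is needed for the effect, a lower number that less compound is needed), compound 1 gives 25 nM, the highest of the three numbers measured so far. Compound 2 `c1ccc(CNC2CCN(CCCc3c[nH]c4ccc(-n5cnnc5)cc34)CC2)cc1` gives 7.6 nM and compound 3 `c1ccc(C2CCCCN2C2CCN(CCCc3c[nH]c4ccc(-n5cnnc5)cc34)CC2)cc1` gives 4.7 nM; both sit beyond the scatter below compound 1.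

The change considered here is 2-(carbamoyloxy)-1-phenylethyl in place of 2,3-dihydro-1H-inden-1-yl on an amine nitrogen, giving compound 4 `NC(=O)OC[C@H](NC1CCN(CCCc2c[nH]c3ccc(-n4cnnc4)cc23)CC1)c1ccccc1`.

Among the compounds with values here, the one measured step that bears on this change is a 3.3-fold lower number from compound 1 to compound 2 (0.52 log units; beyond the scatter), where a simpler phenyl-bearing substituent replaced the same 2,3-dihydro-1H-inden-1-yl on the same nitrogen. Within the data shown here, compound 4 also places a phenyl on that nitrogen, now with a carbamoyloxy-bearing chain attached; no measured compound carries that chain, so its contribution is unknown. Among the measured compounds shown here, on the single step available, a modest lowering of the number is expected, of the order of a 2.5-fold lower number from compound 1 to compound 4 (0.40 log units; beyond the scatter), with wide uncertainty because only a 3.3-fold lower number from compound 1 to compound 2 (0.52 log units; beyond the scatter) informs it. Compound 4 is therefore estimated at 10 nM, within 3 nM to 35 nM.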

Compound 4, half-maximal effective concentration: 9.3 nM
For compound 4 the middle estimate is 1.1-fold (0.03 log units) above the measured one; measured number inside the range.
By their numbers in this assay, from the lowest: compounds 3, 2 and 4 (each within the scatter of the next); then compound 1.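

At the amine nitrogen, 2-(carbamoyloxy)-1-phenylethyl joins benzyl as a second replacement for 2,3-dihydro-1H-inden-1-yl that lowers the number in this assay (a 2.7-fold lower number from compound 1 to compound 4 (0.43 log units; beyond the scatter)). Placing (carbamoyloxy)methyl in place of hydrogen on the saturated chain carbon bound to the amine nitrogen and an aromatic carbon leaves the two compounds unseparated (a 1.2-fold higher number from compound 2 to compound 4 (0.09 log units; within the scatter)), so this added group, with its hydrogen-bond donor and acceptors, shifts the number by no more than the scatter in this one pair. No measured property is available to account for either step.

Still open, from the compounds shown here alone, is how the defined stereocentre of compound 4 bears on the number, and whether a hydroxyl or a primary amine on the same chain carbon would behave like the carbamoyloxy group. A longer chain carrying the carbamoyloxy group also remains an open case.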